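A few compounds are considered here, and "the series" means these few. Any claim that something is new, unique, unknown or untested is made for them only; others in the source may bear on it.

In an ADME assay on A549 cells (Homo sapiens) for cytotoxicity, read by MTT assay (on this read-out higher numbers stand for lower toxicity in this test and lower numbers for higher toxicity in this test), compound 1, with the structure `O=c1[nH]cc(C#CC2CCCCC2)c(=O)[nH]1`, gives 245000 nM. Compound 2, with the structure `CCC#Cc1c[nH]c(=O)[nH]c1=O`, gives 253000 nM in this assay, and the two numbers lie within the usual scatter of each other, so no difference between these two compounds can be claimed from them. Both show weak toxicity toward these cells, despite one carrying a ring on the alkyne and the other a short chain.

Compound 3, with the structure `CCCCC#Cc1c[nH]c(=O)[nH]c1=O`, has not yet been measured in this assay. It differs from compound 2 in one place: ethyl in place of hydrogen on a saturated chain carbon, two bonds along the chain from a triple-bonded carbon. The two measured compounds, which differ far more from each other than compound 3 differs from compound 2, sit within the scatter of each other, so no step beyond the scatter is expected here. The step from compound 2 to compound 3 is expected to be a 1.2-fold lower number from compound 2 to compound 3 (0.06 log units; within the scatter). Compound 3 is therefore estimated at 220000 nM, within a range of 100000 nM to 450000 nM.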

Compound 3, half-maximal cytotoxic concentration: 250000 nM
Compound 3: the middle estimate sits 1.1-fold (0.06 log units) below what was measured; the range from low to high includes it.
By their numbers in this assay, from the lowest: compounds 1, 3 and 2 (each within the scatter of the next).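

In this assay, placing ethyl in place of hydrogen on a saturated chain carbon, two bonds along the chain from a triple-bonded carbon, gives a 1.0-fold lower number from compound 2 to compound 3 (0.01 log units; within the scatter). Going by these compounds alone, this is the first change in a single place that can be read here, and it shows that this test does not separate compound 3 from compound 2, so adding these two carbons at this position makes no difference that can be claimed. No other measurement shown here bears on this result.

On these data alone, what remains open is whether any group at this position would give a number beyond the scatter. An amine or a carboxylic acid in place of the ethyl, or a much longer chain, could either stay with these compounds or part from them, and the data shown do not say which.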